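A few compounds are considered here, and "the series" means these few. Any claim that something is new, unique, unknown or untested is made for them only; others in the source may bear on it.

Three compounds have been measured in a functional assay on MCF7 cells (Homo sapiens), tested at 2.5 uM; a lower number here means a stronger effect, a higher number a weaker effect of the compound at the concentration tested:

compound 1 `C=CCOc1c(C)c(C)c2c(c1C)CCC(C)(COc1cccc(/C=C3\SC(=O)NC3=O)c1)O2` gives 84%
compound 2 `C=CCOc1c(C)c(C)c2c(c1C)CCC(C)(COc1ccc(/C=C3\SC(=O)NC3=O)cc1C)O2` gives 84%
compound 3 `Cc1c(C)c2c(c(C)c1OC(=O)CCC(=O)O)CCC(C)(COc1ccc(/C=C3\SC(=O)NC3=O)cc1)O2` gives 115%

Compound 3 stands highest of these three numbers, which in this assay means the weakest effect. Its nearest neighbour is compound 1, whose number lies lower by an amount beyond the usual scatter; compound 2 lies lower by the same amount. Compounds 1 and 2 sit within the scatter of each other, so no order between them can be claimed.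

Compound 4 `CC(C)=CCOc1c(C)c(C)c2c(c1C)CCC(C)(COc1ccc(/C=C3\SC(=O)NC3=O)cc1)O2` has not yet been measured. Compared with compound 3, the change is 3-methylbut-2-en-1-yl in place of (2-carboxyethyl)carbonyl on an oxygen on an aromatic ring. Going by the values given here, no measured pair shows this exact step, so its size must be guessed. Compound 3 is the only one of the three with the (2-carboxyethyl)carbonyl group, and it is also the one with the weakest effect, whereas compound 1 gives 84% and compound 2 gives 84% without it. The step from compound 3 to compound 4 is therefore expected to be downward, beyond the scatter, a number 30 percentage points lower from compound 3 to compound 4 (beyond the scatter). For compound 4 a value near 85% is estimated, most likely between 65% and 105%.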

Compound 4, a percentage reported as activity, at one concentration (the size of the read-out at that concentration, not a potency): 76%
Compound 4: middle estimate off by 9 percentage points, on the high side, within the range that was stated.
By their numbers in this assay, from the lowest: compounds 4, 1 and 2 (each within the scatter of the next); then compound 3.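

Going by these compounds alone, this is the first step where only one place changes, and it shows that the group on this oxygen matters: in this assay, 3-methylbut-2-en-1-yl in place of (2-carboxyethyl)carbonyl gives a number 39 percentage points lower from compound 3 to compound 4 (beyond the scatter), a stronger effect at the concentration tested. The swap changes several things at once, since the group that leaves has carbon and oxygen atoms, double bonds and a hydrogen-bond donor, while the group that enters has only carbon atoms and no donor or acceptor, so this one step cannot show which of these differences counts. No measurement here explains the size of the step.

Still open, from the compounds shown here alone, is how a saturated pentyl chain, a chain ending in an amine or a bare hydroxyl on this oxygen would compare. Each would help separate the effect of the carboxylic acid from that of the double bond.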